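One Methoxy Group Removed on Two Related Cores

A few compounds are considered here, and "the series" means these few. Any claim that something is new, unique, unknown or untested is made for them only; others in the source may bear on it.

Measured so far, in a functional assay on MDA-MB-435 cells (Homo sapiens) for inhibition, read by sulforhodamine B assay, with a stated time of 48 h; on this read-out higher numbers stand for weaker inhibition of growth and lower numbers for stronger inhibition of growth:
Compound 1, `COc1cc(-c2cc(/C=C/C(=O)c3ccc(N)cc3)[nH]n2)cc(OC)c1OC`, gives 3210 nM.
Compound 2, `COc1ccc(-c2cc(/C=C/C(=O)c3ccc(N)cc3)[nH]n2)cc1OC`, gives 7230 nM.
Compound 3, `COc1cc(C(=O)/C=C/c2cc(-c3cc(OC)c(OC)c(OC)c3)n[nH]2)cc(OC)c1OC`, gives 2950 nM.

Compound 4, `COc1ccc(-c2cc(/C=C/C(=O)c3cc(OC)c(OC)c(OC)c3)[nH]n2)cc1OC`, is not yet measured. It differs from compound 3 by hydrogen in place of methoxy on an aromatic carbon. The same change, (hydrogen in place of methoxy on an aromatic carbon), separates compound 1 from compound 2, and there it gave a 2.3-fold higher number from compound 1 to compound 2 (0.35 log units; beyond the scatter). The difference between the two cores, that of compound 1 and that of compound 3, is not broken down here; their values are within the scatter of each other.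

For compound 4 a step of a 2.3-fold higher number from compound 3 to compound 4 (0.36 log units; beyond the scatter) is expected, because the same change gave a 2.3-fold higher number from compound 1 to compound 2 (0.35 log units; beyond the scatter). Compound 4 is therefore estimated at 6800 nM, most likely between 3200 nM and 15000 nM.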

Compound 4, concentration for total growth inhibition: 4050 nM
Compound 4: middle estimate off by 1.7-fold (0.23 log units), on the high side; measured number inside the range.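

In this assay, hydrogen in place of methoxy on the second core gives a 1.4-fold higher number from compound 3 to compound 4 (0.14 log units; within the scatter). Set beside the earlier step, the two cannot be told apart: the same change on two cores in this assay, a 2.3-fold higher number (0.35 log units; beyond the scatter) from compound 1 to compound 2 and a 1.4-fold higher number (0.14 log units; within the scatter) from compound 3 to compound 4, 1.6-fold (0.22 log units) apart, within the scatter of two such steps. Going by these compounds alone, the data are thus consistent with the change carrying over between these two cores, but only the step on the core of compound 1 lies beyond the scatter, and two pairs show neither a real effect on the core of compound 3 nor how the change would behave on any further core. The compounds shown leave open what other groups would do at this place on the ring, such as a hydroxyl group, a fluorine atom or a longer chain like ethoxy.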